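A few compounds are considered here, and "the series" means these few. Any claim that something is new, unique, unknown or untested is made for them only; others in the source may bear on it.

In a functional assay on a cell-free system (plasma, Oryctolagus cuniculus) for inhibition, with stated times of 5 min, 1 min and 6 min (a lower number here means a stronger inhibitor, a higher number a weaker inhibitor), compound 1 (`C=CCOn1c(-c2cccc(C#N)c2)nc(C)c1C(=O)OCC`) gives 5860 nM and compound 2 (`CCOC(=O)c1c(C)nc(-c2cccc(C#N)c2)n1OCc1ccc(C#N)cc1`) gives 4240 nM while compound 3 (`C=CCOn1c(-c2cccc(C#N)c2)nc(C)c1C(=O)O`) gives 6350 nM as its reading. Compound 3 therefore stands level with the other two, with both of its gaps lying within the scatter of repeated measurements.

Compound 4 (`Cc1nc(-c2cccc(C#N)c2)n(OCc2ccc(C#N)cc2)c1C(=O)O`) differs from compound 3 in one place (4-cyanophenyl in place of vinyl on a saturated chain carbon bound to an oxygen on an aromatic ring) with 4-cyanophenyl in place of vinyl on a saturated chain carbon bound to an oxygen on an aromatic ring. Among the compounds with values here, the same change has been measured once, as a 1.4-fold lower number from compound 1 to compound 2 (0.14 log units; within the scatter) and so gives the only direct guide, though it rests on a single pair. The other measured step, hydrogen in place of ethyl, appears as a 1.1-fold higher number from compound 1 to compound 3 (0.03 log units; within the scatter) and also stays within the scatter, so the step seen from compound 1 to compound 2 may reasonably carry over to compounds bearing that hydrogen. No step beyond the scatter is therefore expected in this assay for this change. The estimated step is a 1.4-fold lower number from compound 3 to compound 4 (0.14 log units; within the scatter) and would be too small to distinguish from repeat variation. For compound 4 the estimate is 4600 nM with an expected range from 2600 nM to 8000 nM around it.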

Compound 4, half-maximal inhibitory concentration: 3880 nM
For compound 4 the middle estimate is 1.2-fold (0.07 log units) above the measured one; the measured number falls inside the stated range.
By their numbers in this assay, from the lowest: compounds 4, 2, 1 and 3 (each within the scatter of the next).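

In this assay, the replacement of allyl by 4-cyanobenzyl has now been read with hydrogen as well as with ethyl on the oxygen next to the carbonyl group, and it gives a 1.6-fold lower number from compound 3 to compound 4 (0.21 log units; within the scatter). Adding a six-membered aromatic ring and a nitrile at this position therefore produced no step beyond the scatter with either group on that oxygen, and the two readings agree: the same change on two cores in this assay, a 1.4-fold lower number (0.14 log units; within the scatter) from compound 1 to compound 2 and a 1.6-fold lower number (0.21 log units; within the scatter) from compound 3 to compound 4, 1.2-fold (0.07 log units) apart, within the scatter of two such steps. The exchange of ethyl for hydrogen, seen earlier only with allyl, can now also be read with 4-cyanobenzyl, where it gives a 1.1-fold lower number from compound 2 to compound 4 (0.04 log units; within the scatter), so it too stays within the scatter with both groups: the same change on two cores in this assay, a 1.1-fold higher number (0.03 log units; within the scatter) from compound 1 to compound 3 and a 1.1-fold lower number (0.04 log units; within the scatter) from compound 2 to compound 4, 1.2-fold (0.07 log units) apart, within the scatter of two such steps.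

With every step here lying within the scatter, the compounds shown identify no change at either place that moves the number in this assay. As far as these compounds go, it remains open whether a saturated propyl chain in place of allyl, an amine in place of the nitrile on the benzyl group, or a primary amide in place of the carboxylic acid would produce a step beyond the scatter.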